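Huh-7 cytotoxicity notes: aryl-to-benzyl swap on the pyrazole nitrogen

A few compounds are considered here, and "the series" means these few. Any claim that something is new, unique, unknown or untested is made for them only; others in the source may bear on it.

Measured so far:
- compound 1, `CN1CCN(CCCNCc2cn(-c3ccc(C(F)(F)F)cc3)nc2-c2ccc(OC(F)(F)F)cc2)CC1`, 2300 nM
- compound 2, `Cc1ccccc1-c1nn(-c2ccc(C(F)(F)F)cc2)cc1CNCCN1CCN(C)CC1`, 11000 nM
- compound 3, `CCCN1CCC(CNCc2cn(-c3ccc(C(F)(F)F)cc3)nc2-c2ccc(C(F)(F)F)cc2)CC1`, 1200 nM

All three numbers come from an ADME assay on Huh-7 cells (Homo sapiens) for cytotoxicity; on this read-out higher numbers stand for lower toxicity in this test and lower numbers for higher toxicity in this test. Among them compound 2 stands highest, so it is the least toxic of the three in this test; its nearest neighbour is compound 1, whose number is lower by a margin beyond the scatter, and compound 3 lies further still below it. Among the compounds with values here, no pair among the measured compounds differs in only one place, so no single-change step is available to lean on.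

The next compound, compound 4, `Cc1ccccc1-c1nn(Cc2ccc(F)cc2)cc1CNCCN1CCN(C)CC1`, is built from compound 2 by one change: 4-fluorobenzyl in place of 4-(trifluoromethyl)phenyl on an aromatic nitrogen. The 2-methylphenyl group and the ((2-(4-methylpiperazin-1-yl)ethyl)amino)methyl group on the shared core are kept as in compound 2.

Nothing measured here isolates the effect of the group on the aromatic nitrogen, so the expected step from compound 2 to compound 4 in this assay is set near zero, within the scatter, with a wide band on either side: a 1.2-fold lower number from compound 2 to compound 4 (0.09 log units; within the scatter). Compound 4 is accordingly estimated at 9000 nM, in the range 3500 nM to 25000 nM, to be confirmed once the measurement is in.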

Compound 4, half-maximal cytotoxic concentration: > 20000 nM
Compound 4: no number, only a limit; the forecaster's own chance of this, stated with the estimate: 10%; middle value at least 2.2-fold (0.34 log units) away from the limit.
By their numbers in this assay, from the lowest: compounds 3 and 1 (each within the scatter of the next); then compound 2. At a limit, above all of these: compound 4.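

Compound 4 reads > 20000 nM in this assay, and this value is a limit of the assay, not a number. The group on the aromatic nitrogen now has its first single-change reading, an at least 1.8-fold higher number from compound 2 to compound 4 (0.25 log units; that floor lies within the scatter), which shows that 4-fluorobenzyl in place of 4-(trifluoromethyl)phenyl, with the 2-methylphenyl group and the ((2-(4-methylpiperazin-1-yl)ethyl)amino)methyl group kept, gives no lower number in this test. The step is only a floor and that floor lies within the scatter, so neither a real gain nor its size can be claimed: the limit of > 20000 nM in this assay, at which 1 of the 4 values shown sits.

The swap changes two things at once, the benzyl link and the ring substituent, so a 4-(trifluoromethyl)benzyl or a 4-fluorophenyl group on the same nitrogen would be needed to tell them apart. On these data alone, it also remains open how a longer chain such as 2-phenylethyl, or a basic amine or carboxylic acid on the aromatic nitrogen, would read against compound 2, and whether the swap holds with other groups on the shared core.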